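Extending the Ester: Compound 4 Against the Dopamine Transporter

The source may report more compounds than this note shows. Statements on the series, on what has been measured and on what is new or still open speak of the compounds shown alone.

In an assay on isolated protein for inhibition of sodium-dependent dopamine transporter (Rattus norvegicus), read by radioligand binding (on this read-out lower numbers stand for stronger inhibition and higher numbers for weaker inhibition), the three measured compounds gave:
Compound 1, `COCCSCC1CN(C)CCC1c1ccc(Cl)cc1`: 50 nM
Compound 2, `COCC[S+]([O-])CC1CN(C)CCC1c1ccc(Cl)cc1`: 15 nM
Compound 3, `CC(=O)OCCSCC1CN(C)CCC1c1ccc(Cl)cc1`: 35 nM

Compound 3 stands second highest of the three numbers: one step is a 1.4-fold lower number from compound 1 to compound 3 (0.15 log units; within the scatter), within the scatter, while the other is a 2.3-fold higher number from compound 2 to compound 3 (0.37 log units; beyond the scatter). Compound 4, `CN1CCC(c2ccc(Cl)cc2)C(CSCCOC(=O)c2ccccc2)C1`, differs from compound 3 by phenyl in place of methyl on a carbonyl carbon. For the measured compounds named here, the step that bears most directly on this change is the one from compound 1 to compound 3, in which acetyl replaced methyl on an oxygen on a saturated carbon and gave a 1.4-fold lower number from compound 1 to compound 3 (0.15 log units; within the scatter). The other two steps are a 3.3-fold lower number from compound 1 to compound 2 (0.52 log units; beyond the scatter) and a 2.3-fold higher number from compound 2 to compound 3 (0.37 log units; beyond the scatter). Each of them involves a different part of the structure. A further enlargement at the carbonyl carbon is therefore expected to move this assay little, if at all beyond the scatter. Compound 4 is estimated at 30 nM, expected between 10 nM and 90 nM, an expected step of a 1.2-fold lower number from compound 3 to compound 4 (0.07 log units; within the scatter).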

Compound 4, inhibition constant: 68 nM
Estimate against measurement, compound 4: 2.3-fold (0.36 log units) below; low and high end bracket the measured number.
By their numbers in this assay, from the lowest: compound 2; then compounds 3, 1 and 4 (each within the scatter of the next).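

In this assay, phenyl in place of methyl on the carbonyl carbon gave a 1.9-fold higher number from compound 3 to compound 4 (0.29 log units; within the scatter) and benzoyl in place of methyl on the oxygen gave a 1.4-fold higher number from compound 1 to compound 4 (0.13 log units; within the scatter), so a six-membered aromatic ring of carbon only is accepted here without a step beyond the scatter. No evidence at hand bears on this result. As far as these compounds go, whether an amine or a longer chain in place of phenyl on the carbonyl carbon would give a step beyond the scatter remains open, as does whether the sulfur change of compound 2 would carry over to the benzoyl ester.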